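Trimming the Acetyl Group to Methyl in Compound 4

The compounds below may be only part of what the source reports. "The series", "measured", "known", "first", "only" and "open" are said of these compounds alone.

Compound 1 `CC(=O)c1c(C)nc2c(OCc3ccccc3)cccn12`: 57%
Compound 2 `Cc1nc2c(OCc3ccccc3)cccn2c1CCC#N`: 40%
Compound 3 `Cc1nc2c(OCc3ccccc3)cccn2c1COC(=O)c1cccnc1`: 87%

These three compounds share one core and were each tested in a functional assay on the whole organism with Rattus norvegicus as the target, with a stated time of 4 h, at a dose of 40 mg/kg by the intraperitoneal route; on this read-out higher numbers stand for more inhibition at the one dose given (going by the name of the read-out) and lower numbers for less inhibition. Compound 1 stands second highest of the three numbers. Its nearest neighbour is compound 2, reached by the step of a number 17 percentage points lower from compound 1 to compound 2 (beyond the scatter), and the furthest is compound 3, whose number stands above that of compound 1 by a gap beyond the scatter.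

The unmeasured compound 4 `Cc1nc2c(OCc3ccccc3)cccn2c1C` differs from compound 1 in one place: methyl in place of acetyl on an aromatic carbon. Going by the values given here, only one measured step bears on this change, namely a number 17 percentage points lower from compound 1 to compound 2 (beyond the scatter), which also replaced the acetyl on that same aromatic carbon and gave a modest fall. The other step, a number 47 percentage points higher from compound 2 to compound 3 (beyond the scatter), lies on the saturated chain carbon and so does not speak to this change directly. Among the compounds with values here, with the acetyl removed and nothing but a methyl entering, a modest drop of a similar size is expected in this assay, though the single supporting step leaves the range wide.

Compound 4 is therefore estimated at 42%, expected to fall between 22% and 62%. The expected step is a number 15 percentage points lower from compound 1 to compound 4 (beyond the scatter).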

Compound 4, a percentage reported as inhibition, in the whole organism at one dose (the size of the read-out at that dose, not a potency): 99%
Beside the measured number, compound 4's estimate is 57 percentage points below it; measured number outside the range, above it.
By their numbers in this assay, from the lowest: compound 2; then compound 1; then compound 3; then compound 4.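

Methyl in place of acetyl on this aromatic carbon next to the ring nitrogen gives a number 42 percentage points higher from compound 1 to compound 4 (beyond the scatter) in this assay and so reverses the direction seen when 2-cyanoethyl replaced acetyl at the same place, which shows that the acetyl carbonyl is not needed for a high number here. The plain methyl also exceeds the longer chains on the saturated carbon, with hydrogen in place of cyanomethyl giving a number 59 percentage points higher from compound 2 to compound 4 (beyond the scatter) and hydrogen in place of ((pyridin-3-yl)carbonyl)oxy giving a number 12 percentage points higher from compound 3 to compound 4 (beyond the scatter) even though that ester had stood well above the others, so among these four compounds the smallest group gives the highest number, with no compound going against this among the methyl-bearing pairs. Nothing shown here accounts for why the smaller group reads higher.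

Still open, on these data alone, is how an ethyl group, an amine or a carboxylic acid on this aromatic carbon would read, and whether hydrogen alone there would hold the number up. All of these numbers come from a single dose, so they give the size of the effect at that dose and leave the potency of each compound unknown.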